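Moving the Oxazolidinedione Ring One Carbon Outward

The compounds below may be only part of what the source reports. "The series", "measured", "known", "first", "only" and "open" are said of these compounds alone.

Compound 2 `CC(C)[C@@H](c1ccc(-c2ccc3cccc(F)c3c2)[nH]c1=O)[C@@H]1OC(=O)NC1=O` was tested in an assay on membranes from Chem-1 cells for displacement of a labelled ligand from prostaglandin E2 receptor EP3 subtype (Homo sapiens), read by scintillation counting, with a stated time of 2 h (a lower number here means a stronger inhibitor, a higher number a weaker inhibitor), where compound 2 gives 85 nM. This is the highest number of the three measured compounds, so compound 2 is the weakest binder of the set: compound 1 `Cc1cc(C(/C=C2\OC(=O)NC2=O)C(C)C)c(=O)[nH]c1-c1ccc2cccc(F)c2c1` gives 23 nM, and compound 3 `C/C(=C1/OC(=O)NC1=O)C(c1ccc(-c2ccc3cccc(F)c3c2)[nH]c1=O)C(C)C` gives 17 nM, both lower by more than the usual scatter. Compound 4 `CC(C)[C@H](C[C@H]1OC(=O)NC1=O)c1ccc(-c2ccc3cccc(F)c3c2)[nH]c1=O` has not been measured. It differs from compound 2 in one place: (2,4-dioxo-1,3-oxazolidin-5-yl)methyl in place of 2,4-dioxo-1,3-oxazolidin-5-yl on a saturated chain carbon bound to an aromatic carbon and a saturated chain carbon. In plain terms, the ring that carries the acidic hydrogen is pushed one carbon further away from the chain carbon it hangs on, while everything else, including the shared core, is kept. Among the measured compounds shown here, no measured pair shows this exact change, so its effect in this assay is uncertain, and a step of either direction is possible. The best guess is a modest move, expected to be within or only slightly beyond the scatter, given as a 1.4-fold higher number from compound 2 to compound 4 (0.15 log units; within the scatter). Compound 4 is therefore estimated at 120 nM, with a plausible range from 35 nM to 450 nM.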

Compound 4, inhibition constant: 6 nM
Beside the measured number, compound 4's estimate is 20-fold (1.30 log units) above it; measured number outside the range, below it.
By their numbers in this assay, from the lowest: compound 4; then compounds 3 and 1 (each within the scatter of the next); then compound 2.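

In this assay, putting (2,4-dioxo-1,3-oxazolidin-5-yl)methyl in place of 2,4-dioxo-1,3-oxazolidin-5-yl gives a 14-fold lower number from compound 2 to compound 4 (1.15 log units; beyond the scatter), a large step from one added carbon. Among the compounds shown here, the earlier compounds differed from one another in more than one place, so this is the first clean reading of a single change here, and it shows that the number responds strongly to how far the ring sits from the saturated chain carbon, even though the ring itself stays the same. Nothing measured here explains why the extra carbon lowers the number.

As far as these compounds go, whether the trend continues with a longer chain, such as a (2,4-dioxo-1,3-oxazolidin-5-yl)ethyl group, remains open. So does whether a carboxylic acid could take the place of the ring on the same methyl link.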